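Series notes: removing the aryl methyl of compound 3

The source may report more compounds than this note shows. Statements on the series, on what has been measured and on what is new or still open speak of the compounds shown alone.

Compound 1, `COc1cccc(/C=C/C(=O)c2sc(Nc3ccccc3)nc2C)c1`: in a functional assay on PC-3 cells (Homo sapiens) for cytotoxicity, read by MTT assay (on this read-out lower numbers stand for stronger inhibition and higher numbers for weaker inhibition), compound 1 stops at > 25000 nM, which is a limit of the assay and not a number.
Compound 2, `Cc1nc(Nc2cccc(Cl)c2)sc1C(=O)/C=C/c1ccccc1`: in this assay compound 2 likewise stops at the limit > 25000 nM.
Compound 3, `Cc1cccc(Nc2nc(C)c(C(=O)/C=C/c3ccccc3)s2)c1`: in this assay compound 3 gives 11700 nM.

Going by the values given here, compound 3 therefore holds the only number in the set; the other two values are limits, as the limit of > 25000 nM in this assay, at which 2 of the 3 values shown sit, records. Among the compounds with values here, the single measured step, an at least 2.1-fold lower number from compound 2 to compound 3 (0.32 log units; beyond the scatter), exchanged chloro for methyl on an aromatic carbon and gave at least a modest lowering, the chloro compound sitting at the limit.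

Compound 4, `Cc1nc(Nc2ccccc2)sc1C(=O)/C=C/c1ccccc1`, is still to be measured. The change from compound 3 is hydrogen in place of methyl on an aromatic carbon, meta to a large group; cut one bond further out, 3-methylphenyl becomes phenyl. Within the data shown here, no measured step removes this methyl outright. The nearest guide is an at least 2.1-fold lower number from compound 2 to compound 3 (0.32 log units; beyond the scatter), which shows that the group at this carbon shifts the number by at least that much. Compound 1, which also carries an unsubstituted anilino group but differs on the other ring, sits at the limit. A step toward weaker inhibition is expected, a 1.9-fold higher number from compound 3 to compound 4 (0.27 log units; within the scatter). Compound 4 is estimated at 22000 nM, between 8000 nM and 60000 nM, with a fair chance that only the limit is reported.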

Compound 4, half-maximal inhibitory concentration: > 25000 nM
Compound 4 was reported as a limit (the forecaster's own chance of this, stated with the estimate: 45%); middle value at least 1.1-fold (0.05 log units) away from the limit.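

Going by these compounds alone, removing the methyl outright gives an at least 2.1-fold higher number from compound 3 to compound 4 (0.32 log units; beyond the scatter), so this position now has a direct comparison with hydrogen, where the earlier compounds offered only the exchange with chloro. In this assay, compound 4 stops at > 25000 nM, a limit of the assay and not a number. Of the three groups compared at this carbon, methyl is thus the only one with a measured number, while hydrogen and chloro both leave the compound at the limit; the steps linking compound 4 to compound 2 and to compound 1 cannot be read, and the size of the methyl step is known only as a minimum: the limit of > 25000 nM in this assay, at which 3 of the 4 values shown sit.

Still open, going by these compounds, is whether the lowering belongs to methyl alone or extends to a larger alkyl group such as ethyl or isopropyl, or to a different group at this carbon such as an amine or a carboxylic acid. The compounds shown also leave open whether a methoxy group on the other ring, as in compound 1, would change the number when paired with 3-methylphenyl.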